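This account rests on a few compounds, and the source may have more. Where it says the series, first, only, none or still open, it means among the compounds named here.

Measured compounds in a physicochemical assay for solubility, read by HPLC, in phosphate buffer, measured as thermodynamic solubility, with a stated time of 48 h, at pH 7.2; a higher number here means a more soluble compound, a lower number a less soluble compound:
- compound 1 `CCCOc1ccc(C[C@@H](Cc2ccccc2)C(=O)O)cc1CNC(=O)c1ccc(-c2cccc(F)c2)cc1`: < 1 ug/mL
- compound 2 `CCCOc1ccc(C[C@@H](Cc2ccccc2)C(=O)O)cc1CNC(=O)c1ccc(-c2ccc(F)cc2)cc1`: < 1 ug/mL

In this assay compound 1 gives < 1 ug/mL, which is a limit of the assay and not a number. Compound 2 likewise gives < 1 ug/mL, again a limit rather than a number. Both measured values sit at the limit of < 1 ug/mL in this assay, at which 2 of the 2 values shown sit, so the pair offers no readable size: the step that the two limits leave unreadable from compound 1 to compound 2 cannot be read in either direction, and compound 1 stands only at a limit, with no number beside it.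

Compound 3 `CCCOc1ccc(C[C@@H](Cc2ccccc2)C(=O)O)cc1CNC(=O)c1ccc(-c2ccccc2)cc1` differs from compound 1 by hydrogen in place of fluoro on an aromatic carbon. Within the data shown here, no measured step bears directly on this change; the single measured step, 4-fluorophenyl in place of 3-fluorophenyl, is itself unreadable. What remains is that both measured compounds, with or without the fluoro at either place, sit at the same limit, and compound 3 keeps the same core, the same acid and the same biphenyl amide.

Compound 3 is therefore expected to return a limit again, estimated at 0.7 ug/mL, within 0.2 ug/mL to 3 ug/mL. The expected step that the limit leaves unreadable from compound 1 to compound 3 is correspondingly not readable beyond the limit.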

Compound 3, solubility: < 1 ug/mL
Compound 3 ended at the assay's limit; the forecaster's own chance of this, stated with the estimate: 80%; the middle value lies beyond the limit too.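

In this assay, no step can be read among compound 1, compound 2 and compound 3, since each of the three gives a limit and not a number: the limit of < 1 ug/mL in this assay, at which 3 of the 3 values shown sit.

The compounds shown leave open whether the 3-fluorophenyl, 4-fluorophenyl and phenyl compounds differ in solubility at all, and by how much.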